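This account rests on a few compounds, and the source may have more. Where it says the series, first, only, none or still open, it means among the compounds named here.

Measured compounds:
- compound 1, `COC(=O)CC1CCN(C[C@H]2CN(c3ccc(-n4cc(-c5ccccn5)cn4)c(F)c3)C(=O)O2)CC1`: 92100 nM
- compound 2, `O=C1O[C@@H](CN2CCC(O)CC2)CN1c1ccc(-n2cc(-c3ccccn3)cn2)c(F)c1`: 45900 nM

In a physicochemical assay for solubility, read by HPLC, with a stated time of 24 h (on this read-out higher numbers stand for higher solubility and lower numbers for lower solubility), compound 1 gives 92100 nM. Compound 2, `O=C1O[C@@H](CN2CCC(O)CC2)CN1c1ccc(-n2cc(-c3ccccn3)cn2)c(F)c1`, gives 45900 nM in this assay. For the measured compounds named here, on these two numbers compound 2 has the lower one, but the one step measured, a 2.0-fold lower number from compound 1 to compound 2 (0.30 log units; within the scatter), lies within the scatter, so the two compounds cannot be told apart on this read-out.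

Compound 3, `O=C1O[C@@H](CN2CCC(c3ccc(F)cc3)CC2)CN1c1ccc(-n2cc(-c3ccccn3)cn2)c(F)c1`, has not yet been measured in this assay. It differs from compound 2 in one place: 4-fluorophenyl in place of hydroxy on a saturated ring carbon. Going by the values given here, no measured step covers an exchange of this kind; the only step on record, a 2.0-fold lower number from compound 1 to compound 2 (0.30 log units; within the scatter), swapped one group for another on the same saturated ring carbon and stayed within the scatter. The change to compound 3 is therefore judged without a direct precedent, starting from the value of compound 2, 45900 nM.

For compound 3 the estimated step is a 5.1-fold lower number from compound 2 to compound 3 (0.71 log units; beyond the scatter). Compound 3 is thus expected to give about 9000 nM in this assay, with a likely range from 2000 nM to 35000 nM.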

Compound 3, solubility: <= 19400 nM
Compound 3 gave a limit, no number; the forecaster's own chance of this, stated with the estimate: 10%; the middle value is on the limit's open side.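

Compound 3 gave a limit and not a number in this assay: the limit of <= 19400 nM in this assay, at which 1 of the 3 values shown sits.

For the compounds shown here, this gives the first step beyond the scatter at this position, the saturated ring carbon three ring bonds from the ring nitrogen: an at least 2.3-fold lower number from compound 2 to compound 3 (0.37 log units; beyond the scatter). Going by these compounds alone, the earlier exchange on this carbon, a 2.0-fold lower number from compound 1 to compound 2 (0.30 log units; within the scatter), did not separate its two compounds, whereas measured against the (methoxycarbonyl)methyl group, 4-fluorophenyl also produces a step beyond the scatter, an at least 4.7-fold lower number from compound 1 to compound 3 (0.67 log units; beyond the scatter), so both exchanges that bring in 4-fluorophenyl separate compound 3 from the earlier compounds on this read-out.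

Since the value of compound 3 is a limit, the true size of both steps stays open, and the compounds shown cannot tell whether the ring of the entering group, its fluorine or its larger count of heavy atoms accounts for the change. Also open, on these data alone, is how a plain phenyl, a primary amine or a carboxylic acid on the same saturated ring carbon would read, and whether any of them would stay within the scatter of compound 2 or fall with compound 3.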